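The source may report more compounds than this note shows. Statements on the series, on what has been measured and on what is new or still open speak of the compounds shown alone.

Measured compounds in a toxicity assay on MDCK cells (Canis lupus familiaris) for cytotoxicity, read by CCK-8 assay, with a stated time of 48 h; on this read-out higher numbers stand for lower toxicity in this test and lower numbers for higher toxicity in this test:
- compound 1 `CCc1ccc(C(=O)NNc2c(Br)cccc2Br)cc1` — limit only: > 100000 nM
- compound 2 `COc1ccccc1C(=O)NNc1c(Br)cccc1Br` — limit only: > 100000 nM
- compound 3 `CCOc1ccc(C(=O)NNc2c(F)cccc2F)cc1` — limit only: > 100000 nM

Compound 1 gives no number in this assay, only the limit > 100000 nM. Compound 2 likewise returns only a limit, > 100000 nM. Compound 3 also stops at a limit, > 100000 nM. All three therefore stand together at the limit of > 100000 nM in this assay, at which 3 of the 3 values shown sit, and nothing in these readings sets compound 1 apart from compound 2 or compound 3; no order among them can be read.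

The open question is compound 4 `O=C(NNc1c(Br)cccc1Br)c1ccc(B(O)O)cc1`. It differs from compound 1 by a group of 3 heavy atoms (1 boron, 2 oxygen; no ring) in place of a group of 2 heavy atoms (2 carbon; no ring), on an aromatic carbon. For the measured compounds named here, no pair among the measured compounds shows a step of this kind, so the only footing is that compound 1 and both others sit at the limit. For compound 4 the expected step of a number no higher from compound 1 to compound 4 (the limit leaves the size open) is none beyond the usual scatter of this assay, with the reading most likely again stopping at the limit rather than resolving a number. Compound 4 is estimated at 100000 nM, expected to fall between 40000 nM and 250000 nM.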

Compound 4, half-maximal cytotoxic concentration: > 100000 nM
Compound 4 ended at the assay's limit (the forecaster's own chance of this, stated with the estimate: 85%); the middle value lies on the limit itself.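

Compound 4 gives > 100000 nM in this assay, which is a limit and not a number. For the compounds shown here, compound 1 also ends at a limit, so no step from compound 1 to compound 4 can be read. The compounds shown leave open whether any change on the shared core gives a measurable cytotoxic concentration, and they show no order among themselves: the limit of > 100000 nM in this assay, at which 4 of the 4 values shown sit.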